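Working notes: the urea terminus on the shared core

The source may report more compounds than this note shows. Statements on the series, on what has been measured and on what is new or still open speak of the compounds shown alone.

Measured so far in a functional assay on HEK293 cells for agonist activity at Vasopressin V2 receptor (Homo sapiens), read by a luciferase reporter and cAMP accumulation; a lower number here means that less compound is needed, a higher number that more compound is needed for the effect:
compound 1 `O=C(NCc1ccc(C(=O)N2CCCCc3ccccc32)c(F)c1)Nc1c(F)cccc1F` gives 180 nM
compound 2 `O=C(NCc1ccc(C(=O)N2CCCCc3ccccc32)c(Cl)c1)Nc1c(F)cccc1F` gives 40 nM
compound 3 `Cc1cc(C(=O)N2CCCCc3ccccc32)ccc1CNC(=O)Nc1ccccc1` gives 130 nM

Compound 3 stands second highest of the three numbers. Its nearest neighbour is compound 1, a gap within the scatter, so the two cannot be ordered; its furthest is compound 2, a gap beyond the scatter. Within the data shown here, the only one-place step measured, a 4.5-fold lower number from compound 1 to compound 2 (0.65 log units; beyond the scatter), concerns a halogen on the aromatic ring and leaves the urea terminus untouched.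

Compound 4 `CCOC(=O)CNC(=O)NCc1ccc(C(=O)N2CCCCc3ccccc32)cc1C` differs from compound 3 by (ethoxycarbonyl)methyl in place of phenyl on an amide-type nitrogen. Among the measured compounds shown here, no measured step bears on this change, so the expectation rests on the change alone and must be wide. The step from compound 3 to compound 4 is expected to be a 3.8-fold higher number from compound 3 to compound 4 (0.59 log units; beyond the scatter), toward a higher number. Compound 4 is estimated at 500 nM in this assay, within a range of 120 nM to 2500 nM.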

Compound 4, half-maximal effective concentration: 140 nM
Compound 4: middle estimate off by 3.6-fold (0.55 log units), on the high side; low and high end bracket the measured number.
By their numbers in this assay, from the lowest: compound 2; then compounds 3, 4 and 1 (each within the scatter of the next).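

In this assay, (ethoxycarbonyl)methyl in place of phenyl on the amide-type nitrogen gives a 1.1-fold higher number from compound 3 to compound 4 (0.03 log units; within the scatter) on this core. For this pair, then, the six-membered aromatic ring at this place is not needed to keep the number, and a chain with no ring and with 2 hydrogen-bond acceptors serves equally. Nothing measured here offers a reason for this.

On these data alone, it remains open whether the ester matters in itself, or whether the free carboxylic acid, a primary amide or a longer chain would hold the number at this place.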